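The source may hold more compounds than are shown below. What is called first, only, known or untested is meant among the compounds shown, and "the series" means these compounds.

Compound 1 `CC(=O)Nc1ccc(S(=O)(=O)NNC(=O)c2cccnc2Nc2ccc(Cl)cc2)cc1` was examined in a functional assay on MCF7 cells (Homo sapiens) for antiproliferative activity; a lower number here means that less compound is tolerated, a higher number that more compound is tolerated. In this assay compound 1 gives > 100000 nM, which is a limit of the assay rather than a measured number. A second compound, compound 2 `O=C(NNS(=O)(=O)c1ccc(F)cc1)c1cccnc1Nc1ccc(Cl)cc1Cl`, carries the same core and was run in the same way. In this assay compound 2 gives > 100000 nM, again a limit and not a number. Among the measured compounds shown here, compound 1 therefore stands at the limit of > 100000 nM in this assay, at which 2 of the 2 values shown sit; no number separates it from compound 2, and no step between measured compounds can be drawn from these two results. Compound 3 `O=C(NNS(=O)(=O)c1ccc(Cl)cc1Cl)c1cccnc1Nc1ccc(Cl)cc1` has not yet been tested in this assay. It differs from compound 1 in a single place: 2,4-dichlorophenyl in place of 4-acetamidophenyl on a sulfonyl sulfur. For the measured compounds named here, because both measured values sit at the limit of > 100000 nM in this assay, at which 2 of the 2 values shown sit, the data offer no direction for a step in this assay, and none beyond the usual scatter is expected. Compound 3 is expected to remain at the limit and is estimated at 100000 nM in this assay, within a range of 30000 nM to 300000 nM. This corresponds to an expected step of a number no higher from compound 1 to compound 3 (the limit leaves the size open).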

Compound 3, concentration lethal to 50% of the cells: > 100000 nM
Compound 3 gave a limit, no number (the forecaster's own chance of this, stated with the estimate: 80%); the middle value lies on the limit itself.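

No step can be read from compound 1 to compound 3 in this assay since both results are limits and not numbers, so the exchange of 4-acetamidophenyl for 2,4-dichlorophenyl on the sulfonyl sulfur remains unreadable: the limit of > 100000 nM in this assay, at which 3 of the 3 values shown sit. The compounds shown leave open whether any group at that place would give a number in this assay rather than a limit.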